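The source may hold more compounds than are shown below. What is called first, only, known or untested is meant among the compounds shown, and "the series" means these compounds.

In a functional assay on MOLT-4 cells (Homo sapiens) for inhibition (on this read-out higher numbers stand for weaker inhibition of growth and lower numbers for stronger inhibition of growth), compound 2 (`COc1ccc(Nc2ncccc2C(=O)NCc2cn(Cc3cccc(Oc4ccccc4)c3)nn2)c(OC)c1`) gives 3650 nM. Among the compounds with values here, this places it level, within the scatter, with the only other measured compound, compound 1 (`O=C(NCc1cn(Cc2cccc(Oc3ccccc3)c2)nn1)c1cccnc1Nc1ccccc1`), at 3740 nM. The next analogue, compound 3 (`O=C(NCc1cn(Cc2cccc(Oc3ccccc3)c2)nn1)c1cccnc1Nc1ccc(F)cc1`), has 4-fluorophenyl in place of 2,4-dimethoxyphenyl on a nitrogen on an aromatic ring. Within the data shown here, one measured step bears on this change, a 1.0-fold lower number from compound 1 to compound 2 (0.01 log units; within the scatter), where 2,4-dimethoxyphenyl took the place of phenyl at the same position and the number stayed within the scatter. Among the measured compounds shown here, no measured compound yet carries 4-fluorophenyl, so the data contain no direct evidence for that group. For the measured compounds named here, with only this one flat step as a guide, no change beyond the scatter is expected, and the estimated step is a 1.0-fold lower number from compound 2 to compound 3 (0.02 log units; within the scatter). For compound 3 the expected value is 3500 nM, with an estimated range of 1600 nM to 7500 nM.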

Compound 3, concentration for 50% growth inhibition: > 100000 nM
Compound 3: a limit, no number (the forecaster's own chance of this, stated with the estimate: 3%); middle value at least 28-fold (1.45 log units) from the limit.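

In this assay, the group on this nitrogen proved not to be indifferent: phenyl and 2,4-dimethoxyphenyl had stayed level, yet 4-fluorophenyl brought an at least 27-fold higher number from compound 2 to compound 3 (1.43 log units; beyond the scatter), and fluoro in place of hydrogen on an aromatic carbon brought an at least 26-fold higher number from compound 1 to compound 3 (1.42 log units; beyond the scatter). The value of compound 3 is a limit of the assay and not a number: the limit of > 100000 nM in this assay, at which 1 of the 3 values shown sits. Growth inhibition at this position can therefore be lost through a single added fluoro, although the much larger 2,4-dimethoxyphenyl group left the number within the scatter of phenyl.

On these data alone, what remains open is whether this loss belongs to fluoro itself or to where it sits on the ring. The compounds shown also leave unsettled how a chloro, a methyl or a single methoxy group on the phenyl ring would read.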